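Amide to Urea on a Shared Sulfonate Core

The compounds below may be only part of what the source reports. "The series", "measured", "known", "first", "only" and "open" are said of these compounds alone.

Three compounds share one core, and none of them separates from the others beyond the usual scatter. Compound 2 `CCCC(=O)Nc1ccc(S(=O)(=O)Oc2ccccc2C(C)C)cc1` gives 6600 nM in a functional assay on MCF7 cells (Homo sapiens) for antiproliferative activity, read by sulforhodamine B assay, with a stated time of 48 h; a higher number here means a weaker inhibitor, a lower number a stronger inhibitor. Compound 3 `CCCC(=O)Nc1ccc(S(=O)(=O)Oc2ccccc2I)cc1` gives 9700 nM, and compound 1 `CC(C)C(=O)Nc1cccc(S(=O)(=O)Oc2ccccc2C(C)C)c1` gives 13000 nM. Compound 2 thus has the lowest of the three numbers, but its gaps to compound 3 and compound 1 both lie within the scatter, so no order among them can be read. The only single-point step shown, a 1.5-fold higher number from compound 2 to compound 3 (0.17 log units; within the scatter), concerns an aromatic substituent and leaves this assay essentially unchanged.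

Compound 4 `CC(C)c1ccccc1OS(=O)(=O)c1ccc(NC(=O)NCCCCl)cc1` is not yet measured. It differs from compound 2 by (3-chloropropyl)amino in place of propyl on a carbonyl carbon. Going by the values given here, no measured pair here touches that part of the molecule: the step from compound 2 to compound 3 lies elsewhere, and compound 1 differs from compound 2 in two places at once. What the data show is that substituent changes on this core so far stay within the scatter. The expectation for compound 4 is therefore no step beyond the scatter, a 1.0-fold lower number from compound 2 to compound 4 (0.01 log units; within the scatter), with a wide range. Compound 4 is estimated at 6500 nM, between 2500 nM and 17000 nM.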

Compound 4, half-maximal inhibitory concentration: 7400 nM
For compound 4 the middle estimate is 1.1-fold (0.06 log units) below the measured one; the range from low to high includes it.
By their numbers in this assay, from the lowest: compounds 2, 4, 3 and 1 (each within the scatter of the next).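

Going by these compounds alone, putting (3-chloropropyl)amino in place of propyl on a carbonyl carbon gives a 1.1-fold higher number from compound 2 to compound 4 (0.05 log units; within the scatter) in this assay, the first reading of a single change at this position. The earlier single-place step concerned only an aromatic substituent, whereas this one shows that the number stays within the scatter even when the amide becomes a urea and the chain gains a nitrogen, a chlorine and a hydrogen-bond donor. No measurement on hand explains this outcome.

The compounds shown leave open whether the chlorine and the added nitrogen each leave the number unchanged when taken alone, since both enter together and a plain propylamino group without the chlorine does not appear among them. They also leave open whether a much longer chain, a terminal amine or a carboxylic acid on this carbonyl carbon would move the number beyond the scatter, and whether the same urea would behave alike on the iodo-bearing core of compound 3.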